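From an ester to a hydroxymethyl on a shared core

This account rests on a few compounds, and the source may have more. Where it says the series, first, only, none or still open, it means among the compounds named here.

The compounds here share one core that carries two phenyl groups and a nitrile. Compound 1 `COc1cccc(C(=O)Oc2c(-c3ccccc3)c(-c3ccccc3)n3ccc(C#N)cc23)c1` bears a ((3-methoxyphenyl)carbonyl)oxy group on that core, but in an assay for inhibition of Polyunsaturated fatty acid lipoxygenase ALOX15 (Oryctolagus cuniculus) (a higher number here means a weaker inhibitor, a lower number a stronger inhibitor), compound 1 is recorded as "not determined" (no result reported), so there is no single number on which it can be placed. A relative with a different group on the core, compound 2 `N#Cc1ccn2c(-c3ccccc3)c(-c3ccccc3)c(OCOCc3ccccc3)c2c1`, gives in this assay a value of 39000 nM, which on its own shows that a high concentration is needed for half-maximal inhibition with this core. Compound 3 `N#Cc1ccn2c(-c3ccccc3)c(-c3ccccc3)c(CO)c2c1` arises from compound 1 by the change (hydroxymethyl in place of ((3-methoxyphenyl)carbonyl)oxy on an aromatic carbon). Compound 1 has no number, so the size of the step from compound 1 to compound 3 in this assay cannot be computed, and no direction beyond the usual scatter can be claimed from what is known. The expectation for compound 3 therefore rests on compound 2, whose value of 39000 nM points to weak inhibition from this core. Compound 3 is estimated to fall near 30000 nM, with a plausible range from 8000 nM to 100000 nM.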

Compound 3, half-maximal inhibitory concentration: 34000 nM
The estimate for compound 3 lay 1.1-fold (0.05 log units) below the measured number, and the stated range covers the measured number.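

In this assay, putting hydroxymethyl in place of (benzyloxy)methoxy on this aromatic carbon gives a 1.1-fold lower number from compound 2 to compound 3 (0.06 log units; within the scatter), so the two compounds cannot be told apart. Among these compounds, this is the first comparison that can be read at this place on the shared core, and it shows that two quite different groups give the same result here: compound 2 gives 39000 nM, compound 3 gives 34000 nM, and with either group a high concentration is still needed for half-maximal inhibition. No measured evidence is available to explain why these two groups read alike.

As far as these compounds go, what a carboxylic acid or an amine on this aromatic carbon would do stays open, and so does whether any such group could move the number beyond the usual scatter. From the compounds shown here alone, compound 1 has no number, so steps involving its ((3-methoxyphenyl)carbonyl)oxy group cannot be read, and whether that ester differs from the other two groups remains unknown.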